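Cytotoxicity limits across a dienone series with nitrophenyl variants

This account rests on a few compounds, and the source may have more. Where it says the series, first, only, none or still open, it means among the compounds named here.

The series shares a dienone core bearing two arylidene arms, one of which carries a nitro group and the other a para substituent. Compound 1 `CN(C)c1ccc(/C=C2\CCC/C(=C\c3ccccc3[N+](=O)[O-])C2=O)cc1` carries a dimethylamino group and a 2-nitrophenyl arm. In an ADME assay on HPC cells (Homo sapiens) for cytotoxicity, with a stated time of 24 h (a lower number here means that less compound is tolerated, a higher number that more compound is tolerated), compound 1 gives > 400000 nM, which is a limit of the assay and not a number. Compound 2 `Cc1ccc(/C=C2\CCC/C(=C\c3ccccc3[N+](=O)[O-])C2=O)cc1` arises from compound 1 by methyl in place of dimethylamino on an aromatic carbon. In this assay compound 2 gives > 400000 nM, again a limit. The step that the two limits leave unreadable from compound 1 to compound 2 therefore cannot be sized. Compound 3 `CN(C)c1ccc(/C=C2\CCC/C(=C\c3ccc([N+](=O)[O-])cc3)C2=O)cc1` differs from compound 1 in its core: 4-nitrophenyl in place of 2-nitrophenyl on a double-bonded chain carbon bound to a double-bonded ring carbon. In this assay compound 3 gives > 400000 nM, once more a limit, so a step that the two limits leave unreadable from compound 1 to compound 3 is likewise unreadable. Compound 4 `Cc1ccc(/C=C2\CCC/C(=C\c3ccc([N+](=O)[O-])cc3)C2=O)cc1`, not yet measured, arises from compound 3 by methyl in place of dimethylamino on an aromatic carbon; the place line reads the same as for the change from compound 1 to compound 2, so this is the same change on a core that differs only in the nitrophenyl arm. Within the data shown here, every value so far sits at the limit of > 400000 nM in this assay, at which 3 of the 3 values shown sit. On that basis compound 4 is expected to tolerate a comparable amount of compound, with an estimate of 500000 nM in this assay and an expected step that the limit leaves unreadable from compound 3 to compound 4 that most likely reads as another limit rather than a number. Whether the measurement of compound 4 breaks from this pattern remains to be seen.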

Compound 4, half-maximal cytotoxic concentration: 92000 nM
For compound 4 the middle estimate is 5.4-fold (0.74 log units) above the measured one, outside the stated range (below it).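

In this assay, methyl in place of dimethylamino on the core bearing the 4-nitrophenyl arm gives an at least 4.3-fold lower number from compound 3 to compound 4 (0.63 log units; beyond the scatter), so on this core less compound is tolerated with methyl than with dimethylamino, by a margin beyond the usual scatter. The same change on the core bearing the 2-nitrophenyl arm cannot be read, and neither can the change of nitrophenyl arm, since both compounds in each of those pairs sit at a limit of the assay. The new step therefore shows an effect on one core only and does not show whether the change carries over to the other core, or whether it is smaller, equal or absent there, and the values remain dominated by the limit: the limit of > 400000 nM in this assay, at which 3 of the 4 values shown sit.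

Still open, on these data alone, is whether the drop belongs to methyl itself or to methyl paired with the 4-nitrophenyl arm, and a nitrile in place of the nitro group on that arm would bear on this. Also open, as far as these compounds go, is how a primary amine, a carboxylic acid or a longer chain such as ethyl on that aromatic carbon would read, as a number or as another limit.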